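A few compounds are considered here, and "the series" means these few. Any claim that something is new, unique, unknown or untested is made for them only; others in the source may bear on it.

Compound 2 `C=CCn1c(SCC(=O)c2ccccc2)nnc1-c1ccc(OC)cc1` carries a benzoyl group on a saturated chain carbon bound to a sulfur, and the other two measured compounds are best seen in relation to it. In a functional assay on the whole organism (strain albino) for inhibition, with Rattus norvegicus as the target, read by paw edema, with a stated time of 4 h, at a dose of 0.28 mmol/kg by the oral route (a lower number here means less inhibition, a higher number more inhibition at the dose given (going by the name of the read-out)), compound 2 gives 67%. Compound 1 `C=CCn1c(SC/C(=N/O)c2ccccc2)nnc1-c1ccc(OC)cc1` differs from compound 2 in one place only: a group of 9 heavy atoms (7 carbon, 1 nitrogen, 1 oxygen; one six-membered aromatic ring of carbon only) in place of a group of 8 heavy atoms (7 carbon, 1 oxygen; one six-membered aromatic ring of carbon only), on a saturated chain carbon bound to a sulfur. In this assay compound 1 gives 76%, and the change comes out as a number 9 percentage points higher from compound 2 to compound 1 (within the scatter). Compound 3 `CCn1c(SCC(=O)c2ccccc2)nnc1-c1cc(OC)c(OC)c(OC)c1` keeps the benzoyl group of compound 2 but sits on a different core; the difference between the two cores is not broken down here. In this assay compound 3 gives 72%, a number within the usual scatter of both compound 1 and compound 2.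

Compound 4 `CCn1c(SC/C(=N/O)c2ccccc2)nnc1-c1cc(OC)c(OC)c(OC)c1` has not yet been measured. It stands to compound 3 as compound 1 stands to compound 2: a group of 9 heavy atoms (7 carbon, 1 nitrogen, 1 oxygen; one six-membered aromatic ring of carbon only) in place of a group of 8 heavy atoms (7 carbon, 1 oxygen; one six-membered aromatic ring of carbon only), on a saturated chain carbon bound to a sulfur. The place is the same in both pairs, a saturated chain carbon bound to a sulfur, so this is the same change seen on the other core. Among the compounds with values here, the one example of it so far, from compound 2 to compound 1, moved the number by a number 9 percentage points higher from compound 2 to compound 1 (within the scatter), a small step. A step of similar size is expected here, a number 7 percentage points higher from compound 3 to compound 4 (within the scatter), because the earlier step of a number 9 percentage points higher from compound 2 to compound 1 (within the scatter) was small and because compound 3 starts from 72%. Compound 4 is therefore expected to give about 79% in this assay, with a likely range from 68% to 88%.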

Compound 4, a percentage reported as inhibition, in the whole organism at one dose (the size of the read-out at that dose, not a potency): 79%
Beside the measured number, compound 4's estimate shows no gap at the digits printed; measured number inside the range.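

On the core of compound 3, putting the new nitrogen-bearing group in place of benzoyl, on a saturated chain carbon bound to a sulfur, comes out in this assay as a number 7 percentage points higher from compound 3 to compound 4 (within the scatter). Set beside the same change on the core of compound 1, this gives no sign that the core alters the size of the step: the same change on two cores in this assay, a number 9 percentage points higher (within the scatter) from compound 2 to compound 1 and a number 7 percentage points higher (within the scatter) from compound 3 to compound 4, 2 percentage points apart, within the scatter of two such steps

This agreement supports carrying the change from one of these cores to the other with a similar result, but it does not show that the change itself improves inhibition, as each step on its own lies within the scatter, and two pairs say nothing about any further core.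

The compounds shown leave open which of the features that separate the two cores accounts for any part of their numbers, as no pair here isolates one such feature. On these data alone, it also remains open how this assay would respond to a quite different group on the saturated chain carbon bound to a sulfur, such as a carboxylic acid, an amine or a longer chain.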